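This account rests on a few compounds, and the source may have more. Where it says the series, first, only, none or still open, it means among the compounds named here.

In a functional assay on MCF7 cells (Homo sapiens) for antiproliferative activity, read by MTT assay, with a stated time of 24 h (on this read-out higher numbers stand for weaker inhibition and lower numbers for stronger inhibition), compound 1 `CCCCNC(=O)COc1ccc(C(=O)c2c(CCCC)oc3ccccc23)cc1` gives > 50000 nM, which is a limit of the assay and not a number. Compound 2 `CCCCc1oc2ccccc2c1C(=O)c1ccc(OCC(=O)N2CCCC2)cc1` gives 42400 nM and compound 3 `CCCCc1oc2ccccc2c1C(=O)c1ccc(OCC(=O)Nc2cccc(OC)c2)cc1` gives 38500 nM. Going by the values given here, these are the only two numbers so far, and they stand together: a 1.1-fold lower number from compound 2 to compound 3 (0.04 log units; within the scatter). Compound 3 therefore sits in the same weak range as the other amides, with no measured separation from them.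

Next is compound 4 `CCCCc1oc2ccccc2c1C(=O)c1ccc(OCC(=O)N[C@H](C)c2ccccc2)cc1`, which carries 1-phenylethyl in place of 3-methoxyphenyl on an amide-type nitrogen. The entering group has one defined stereocentre.

Among the compounds with values here, three measured steps bear on this change, since all of them vary the same amide substituent. Going from butyl to 3-methoxyphenyl gave an at least 1.2-fold lower number from compound 1 to compound 3 (0.11 log units; that floor lies within the scatter). Going from butylamino to pyrrolidin-1-yl gave an at least 1.1-fold lower number from compound 1 to compound 2 (0.07 log units; that floor lies within the scatter). Both of these are floors set by the limit of > 50000 nM in this assay, at which 1 of the 3 values shown sits, and neither floor rises above the scatter. So far, then, exchanging this substituent has produced no resolved change in this assay, and no step beyond the scatter is expected here. The expected change is a 1.0-fold higher number from compound 3 to compound 4 (0.02 log units; within the scatter). The estimated value for compound 4 is 40000 nM, with an expected range from 20000 nM to 65000 nM.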

Compound 4, half-maximal inhibitory concentration: 14100 nM
Beside the measured number, compound 4's estimate is 2.8-fold (0.45 log units) above it, outside the stated range (below it).
By their numbers in this assay, from the lowest: compound 4; then compounds 3 and 2 (each within the scatter of the next). At a limit, above all of these: compound 1.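

In this assay the substituent on the amide-type nitrogen gives its first resolved steps, with a 2.7-fold lower number from compound 3 to compound 4 (0.44 log units; beyond the scatter) for 1-phenylethyl in place of 3-methoxyphenyl, and a 3.0-fold lower number from compound 2 to compound 4 (0.48 log units; beyond the scatter) for (1-phenylethyl)amino in place of pyrrolidin-1-yl on the carbonyl carbon. The leaving 3-methoxyphenyl and the entering 1-phenylethyl each hold one six-membered aromatic ring of carbon only and have equal heavy-atom counts, so the presence of such a ring does not account for the step; the entering group lacks the oxygen and carries a defined stereocentre, and these compounds cannot tell which of these differences, if either, matters. Against the butyl amide the step is only a floor, an at least 3.5-fold lower number from compound 1 to compound 4 (0.54 log units; beyond the scatter), since compound 1 stands at a limit of the assay: the limit of > 50000 nM in this assay, at which 1 of the 4 values shown sits.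

Going by these compounds, it remains open whether the step belongs to the 1-phenylethyl group as a whole, which a plain benzyl group, the mirror-image 1-phenylethyl group or a longer chain ending in phenyl would test. Also open, on these data alone, is whether an amine or a carboxylic acid on that phenyl ring would keep the step in this assay.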